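The source may report more compounds than this note shows. Statements on the series, on what has been measured and on what is new or still open speak of the compounds shown alone.

In a functional assay on RAW264.7 cells (Mus musculus) for inhibition (a lower number here means a stronger inhibitor, a higher number a weaker inhibitor), compound 1 (`CCOC(=O)C1=CCCCC1S(=O)(=O)Nc1ccccc1F`) gives 75 nM and compound 2 (`CCOC(=O)C1=CCCCC1S(=O)(=O)Nc1cccc(Cl)c1`) gives 66 nM. For the measured compounds named here, compound 2 therefore stands level with the only other measured compound, as the two numbers lie within the scatter of each other. Compound 3 (`CCOC(=O)C1=CCCCC1S(=O)(=O)Nc1ccc(Cl)cc1`) carries 4-chlorophenyl in place of 3-chlorophenyl on a sulfonamide nitrogen. Going by the values given here, one measured step bears on this change: a 1.1-fold lower number from compound 1 to compound 2 (0.06 log units; within the scatter). It also swaps the group on the sulfonamide nitrogen and stays within the scatter. Among the compounds with values here, no measured compound carries 4-chlorophenyl, so this evidence is indirect and thin. No step beyond the scatter is expected in this assay, in either direction. The expected step is a 1.1-fold higher number from compound 2 to compound 3 (0.03 log units; within the scatter). The estimate for compound 3 is 70 nM, with an expected range of 25 nM to 200 nM.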

Compound 3, half-maximal inhibitory concentration: 400 nM
For compound 3 the middle estimate is 5.7-fold (0.76 log units) below the measured one; measured number above the stated range.
By their numbers in this assay, from the lowest: compounds 2 and 1 (each within the scatter of the next); then compound 3.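

The group on the sulfonamide nitrogen matters in this assay: 4-chlorophenyl in place of 3-chlorophenyl gives a 6.1-fold higher number from compound 2 to compound 3 (0.78 log units; beyond the scatter) even though the two groups hold the same atoms, joined differently. Against 2-fluorophenyl, 4-chlorophenyl gives a 5.3-fold higher number from compound 1 to compound 3 (0.73 log units; beyond the scatter), so 4-chlorophenyl alone stands apart among the three compounds, while 2-fluorophenyl and 3-chlorophenyl remain within the scatter of each other. No available evidence accounts for these steps.

Open, going by these compounds, is whether the higher number belongs to 4-chlorophenyl alone or extends to groups such as 4-fluorophenyl, 4-methoxyphenyl or 2-chlorophenyl on the sulfonamide nitrogen. Also open, on these data alone, is whether these steps would hold with a carboxylic acid in place of the ethyl ester of the shared core.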